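Methoxy for bromo on the anilino ring: permeability notes

The source may hold more compounds than are shown below. What is called first, only, known or untested is meant among the compounds shown, and "the series" means these compounds.

Compound 2 `CNC(=O)c1cc(Oc2ccc3nc(Nc4ccc(Br)cc4)ncc3c2)ccn1` is the reference point here. In an ADME assay on Caco-2 cells (Homo sapiens) for permeability, in the apical to basolateral direction (on this read-out lower numbers stand for lower permeability and higher numbers for higher permeability), compound 2 gives < 1 10^-6 cm/s, which is a limit of the assay rather than a number. Its companion compound 1 `CNC(=O)c1cc(Oc2ccc3nc(Nc4cccc(Br)c4)ncc3c2)ccn1` is the same read-out at < 1 10^-6 cm/s, again a limit. Going by the values given here, the one step between measured compounds, a step that the two limits leave unreadable from compound 1 to compound 2, therefore cannot be read, and the picture is summed up by the limit of < 1 10^-6 cm/s in this assay, at which 2 of the 2 values shown sit.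

Compound 3 `CNC(=O)c1cc(Oc2ccc3nc(Nc4ccc(OC)cc4)ncc3c2)ccn1` has not yet been run in this assay. Relative to compound 2 the change is methoxy in place of bromo on an aromatic carbon. Among the compounds with values here, no measured step bears on a swap of bromo for methoxy, and the single step that exists is unreadable, so nothing here sizes the move in this assay in either direction. With both measured compounds sitting at the limit, the expectation for compound 3 is a value close to that limit, with a fair chance that only a limit is reported again. Compound 3 is estimated at 1 10^-6 cm/s, in the range 0.4 10^-6 cm/s to 3 10^-6 cm/s, which corresponds to an expected step of a number no lower from compound 2 to compound 3 (the limit leaves the size open).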

Compound 3, apparent permeability: < 1 10^-6 cm/s
Compound 3: no number, only a limit; the forecaster's own chance of this, stated with the estimate: 55%; the middle value sits exactly at the limit.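

In this assay, going by these compounds alone, compound 3 gives < 1 10^-6 cm/s, a limit of the assay and not a number, so no step among compound 1, compound 2 and compound 3 can be read. The compounds shown leave open what number each would give, and whether methoxy in place of bromo changes the read-out at all, since all rest on one reading: the limit of < 1 10^-6 cm/s in this assay, at which 3 of the 3 values shown sit.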